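Sulfamoyl in place of methoxycarbonyl on compound 3

The source may hold more compounds than are shown below. What is called first, only, known or untested is meant among the compounds shown, and "the series" means these compounds.

In an ADME assay on MT4 cells (Homo sapiens) for cytotoxicity (a higher number here means that more compound is tolerated, a lower number that less compound is tolerated), three close relatives sharing one core have been measured so far. Compound 1 `Cc1cc(C)cc(S(=O)(=O)n2c(SCC(=O)Nc3ccccc3Cl)nc3ccccc32)c1` gives 107000 nM. Among the measured compounds shown here, compound 3 `COC(=O)c1ccc(NC(=O)CSc2nc3ccccc3n2S(=O)(=O)c2cc(C)cc(C)c2)c(Cl)c1` gives 145000 nM, and this value lies within the usual scatter of the one for compound 1, so the two stand level. Compound 2 `Cc1cc(C)cc(S(=O)(=O)n2c(SCC(=O)Nc3ccccc3[N+](=O)[O-])nc3ccccc32)c1` is reported only as a limit, >= 26000 nM. This leaves a step that the limit leaves unreadable from compound 1 to compound 2, so that comparison offers no size to work with.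

The next compound, compound 4 `Cc1cc(C)cc(S(=O)(=O)n2c(SCC(=O)Nc3ccc(S(N)(=O)=O)cc3Cl)nc3ccccc32)c1`, carries sulfamoyl in place of methoxycarbonyl on an aromatic carbon, para to a large group and meta to a chloro group (sulfamoyl in place of methoxycarbonyl on an aromatic carbon). For the measured compounds named here, no measured compound carries sulfamoyl, so the closest guide is the one measured step at this same place. Compound 3 has methoxycarbonyl where compound 1 has hydrogen, and that was a 1.4-fold higher number from compound 1 to compound 3 (0.13 log units; within the scatter). Putting a group at this place therefore did not shift this assay beyond the scatter, and a similar outcome is expected here, though with real uncertainty for a group not yet tested. The expected result is a 1.2-fold lower number from compound 3 to compound 4 (0.08 log units; within the scatter). Compound 4 is estimated at 120000 nM, with an expected range from 50000 nM to 260000 nM.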

Compound 4, half-maximal cytotoxic concentration: 25600 nM
For compound 4 the middle estimate is 4.7-fold (0.67 log units) above the measured one; measured number outside the range, below it.
By their numbers in this assay, from the lowest: compound 4; then compounds 1 and 3 (each within the scatter of the next).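

This position is not indifferent after all. In this assay, hydrogen and methoxycarbonyl stand level here, yet sulfamoyl gives a 5.7-fold lower number from compound 3 to compound 4 (0.75 log units; beyond the scatter) and a 4.2-fold lower number from compound 1 to compound 4 (0.62 log units; beyond the scatter), so the identity of the group matters and not merely whether the position is filled. Methoxycarbonyl and sulfamoyl have the same number of heavy atoms, so that count does not separate them, although sulfamoyl brings a hydrogen-bond donor that methoxycarbonyl lacks and a sulfur atom in place of carbon. The comparison with compound 2 rests on a limit, which makes an at least 1.0-fold lower number from compound 2 to compound 4 (0.00 log units; that floor lies within the scatter) a floor only, because compound 2 has no exact number: the limit of >= 26000 nM in this assay, at which 1 of the 4 values shown sits.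

As far as these compounds go, what goes with the lower number remains open, since the donor and the sulfur enter together in compound 4. A methylsulfonyl group at this place would keep the sulfur without the donor, and a carboxamide would keep a donor without the sulfur, so these two groups could begin to separate the two changes.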